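One Added Methyl on a Strong Growth Inhibitor

The source may hold more compounds than are shown below. What is called first, only, known or untested is meant among the compounds shown, and "the series" means these compounds.

Compound 1 `Cc1ccc2c(O)cc(-c3cccc(Cl)c3)nc2n1`: 31.6 nM
Compound 2 `Cc1ccnc2nc(-c3cccc4ccccc34)cc(O)c12`: < 10 nM

These values come from a functional assay on SK-MEL-5 cells (Homo sapiens) for antiproliferative activity; a lower number here means a stronger inhibitor of growth, a higher number a weaker inhibitor of growth. Compound 2 has no exact number, only the limit < 10 nM. Compound 3 `Cc1cc(C)c2c(O)cc(-c3cccc4ccccc34)nc2n1` differs from compound 2 by one change, (methyl in place of hydrogen on an aromatic carbon), with methyl in place of hydrogen on an aromatic carbon, next to the ring nitrogen. Within the data shown here, no measured pair shows what this change does in this assay. A small move towards weaker growth inhibition is expected, possibly none beyond the scatter, and the estimated step is a number no lower from compound 2 to compound 3 (the limit leaves the size open). For compound 3 the estimated value is 10 nM, with an expected range from 3 nM to 40 nM.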

Compound 3, concentration for 50% growth inhibition: 468 nM
The estimate for compound 3 lay 47-fold (1.67 log units) below the measured number; measured number outside the range, above it.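

In this assay, methyl in place of hydrogen on an aromatic carbon, next to the ring nitrogen, is far from a neutral change: it brings an at least 46-fold higher number from compound 2 to compound 3 (1.67 log units; beyond the scatter). In this one pair, a single added carbon at this position costs much of the growth inhibition. The value of compound 2 is a limit and not a number, and the step rests on it: the limit of < 10 nM in this assay, at which 1 of the 3 values shown sits.

The compounds shown leave open whether only methyl has this effect at this position. An amine or an ethyl chain in the same place could give a very different number.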